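The compounds below may be only part of what the source reports. "The series", "measured", "known", "first", "only" and "open" are said of these compounds alone.

Compound 1 `N#CC1=C(N)Oc2cc3oc(-c4ccccc4)cc(=O)c3c(O)c2C12C(=O)Nc1ccccc12` heads a small set of three compounds built on one shared core and tested in a functional assay on PC-3 cells (Homo sapiens) for antiproliferative activity, read by MTT assay, with a stated time of 48 h; on this read-out higher numbers stand for weaker inhibition and lower numbers for stronger inhibition. In this assay compound 1 gives > 50000 nM, which is a limit of the assay and not a number. Compound 2 `Cc1ccc2c(c1)C1(C(=O)N2)C(C#N)=C(N)Oc2cc3oc(-c4ccccc4)cc(=O)c3c(O)c21`, carrying a methyl in place of hydrogen on an aromatic carbon, gives in this assay > 50000 nM, again a limit. Compound 3 `N#CC1=C(N)Oc2cc3oc(-c4ccccc4)cc(=O)c3c(O)c2C12C(=O)Nc1c(Cl)cccc12`, carrying chloro in place of hydrogen on an aromatic carbon, gives in this assay > 50000 nM, also a limit. The step that the two limits leave unreadable from compound 1 to compound 2 therefore cannot be read, and neither can the step that the two limits leave unreadable from compound 1 to compound 3; what remains is the limit of > 50000 nM in this assay, at which 3 of the 3 values shown sit. Compound 1 thus has no definite place on the numbers shown, only its limit.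

Compound 4 `N#CC1=C(N)Oc2cc3oc(-c4ccccc4)cc(=O)c3c(O)c2C12C(=O)Nc1cc(Br)ccc12` differs from compound 1 by bromo in place of hydrogen on an aromatic carbon. Both measured steps from compound 1 bear on this change, each replacing a hydrogen on an aromatic carbon of the shared core, yet both are unreadable in size, so they give no direction. Because the limit of > 50000 nM in this assay, at which 3 of the 3 values shown sit, covers compound 1 and both of its neighbours, compound 4 is expected to rest at the limit as well, with no step beyond the scatter. The step that the limit leaves unreadable from compound 1 to compound 4 is the one expected. For compound 4 in this assay the estimate is 80000 nM, ranging from 30000 nM to 300000 nM.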

Compound 4, half-maximal inhibitory concentration: 24800 nM
Compound 4: middle estimate off by 3.2-fold (0.51 log units), on the high side; measured number outside the range, below it.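

In this assay, within the data shown here, bromo on this aromatic carbon, meta to a fused ring and para to a fused ring, yields the only definite number in the set, and the change reads as an at least 2.0-fold lower number from compound 1 to compound 4 (0.30 log units; that floor lies within the scatter). That size is only a floor set by the limit of compound 1, and it does not by itself establish a change beyond the scatter, while the steps to the methyl and chloro compounds still cannot be read. The result does show that the shared core can give a measurable number in this assay when it carries a bromo group, and compound 4 alone leaves the limit that holds the rest of the set: the limit of > 50000 nM in this assay, at which 3 of the 4 values shown sit.

The compounds shown leave open how far compound 1 really lies from compound 4, so the true size of the bromo step remains unknown. They also leave open whether an iodo, a methoxy, an amine or a carboxylic acid on this same aromatic carbon would give a definite number, and whether such a number would be lower or higher than that of compound 4.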